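A few compounds are considered here, and "the series" means these few. Any claim that something is new, unique, unknown or untested is made for them only; others in the source may bear on it.

In a functional assay on HepG2 cells (Homo sapiens) for inhibition, read by MTT assay (a lower number here means a stronger inhibitor of growth, a higher number a weaker inhibitor of growth), compound 1 `COc1ccccc1C(=O)Nc1cccc(-c2cc(=O)c3c(OC)c(OC)c(OC)cc3o2)c1` gives 7530 nM. Compound 2 `COc1ccc(C(=O)Nc2cccc(-c3cc(=O)c4c(O)c(OC)c(OC)cc4o3)c2)cc1` stands at > 100000 nM, which is a limit of the assay and not a number. Compound 3 `COc1ccccc1C(=O)Nc1cccc(-c2cc(=O)c3c(O)c(OC)c(OC)cc3o2)c1` differs from compound 2 by one change, 2-methoxyphenyl in place of 4-methoxyphenyl on a carbonyl carbon. For the measured compounds named here, no measured step covers this change, so its size is uncertain. A modest move toward stronger inhibition is expected, with the estimated step being an at least 2.5-fold lower number from compound 2 to compound 3 (0.39 log units; beyond the scatter). Going by the values given here, the strong end of the range is set by compound 1 at 7530 nM, the only measured number. For compound 3 the expected value is 40000 nM, with an estimated range of 8000 nM to 100000 nM.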

Compound 3, concentration for 50% growth inhibition: > 100000 nM
Compound 3 gave a limit, no number; the forecaster's own chance of this, stated with the estimate: 40%; middle value at least 2.5-fold (0.39 log units) away from the limit.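

Hydrogen in place of methyl on an oxygen on an aromatic ring gives an at least 13-fold higher number from compound 1 to compound 3 (1.12 log units; beyond the scatter) in this assay, the first readable step in the series. With that change in place, 2-methoxyphenyl on the carbonyl carbon does not restore a measurable value: compound 3 gives > 100000 nM, a limit and not a number. The step between the two methoxyphenyl isomers cannot be read because both values are limits: the limit of > 100000 nM in this assay, at which 2 of the 3 values shown sit.

Still open, from the compounds shown here alone, is whether 4-methoxyphenyl in place of 2-methoxyphenyl changes the value when the methyl stays on that oxygen. Also open, going by these compounds, is how an aminophenyl group on the carbonyl carbon would read.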